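This account rests on a few compounds, and the source may have more. Where it says the series, first, only, none or still open, it means among the compounds named here.

Measured compounds:
compound 1, `CC(C)[C@@H](NC(=O)CCc1ccc(F)cc1)C(=O)N1CCC(c2ccc(Cl)cc2)CC1`: 70 nM
compound 2, `Cc1ccccc1CCC(=O)N[C@@H](C(=O)N1CCC(c2ccc(Cl)cc2)CC1)C(C)C`: 19 nM

Both compounds share a core that differs only in the aromatic group at the far end of the chain. In an assay on THP-1 cells for displacement of a labelled ligand from C-C chemokine receptor type 1 (Homo sapiens) (a lower number here means a stronger inhibitor, a higher number a weaker inhibitor), compound 1 gives 70 nM and compound 2 gives 19 nM. Within the data shown here, the single measured step, a 3.7-fold lower number from compound 1 to compound 2 (0.57 log units; beyond the scatter), comes from swapping 2-methylphenyl for 4-fluorophenyl on a saturated chain carbon two bonds along from the carbonyl carbon. On the numbers shown, compound 2 stands lowest of the two, with compound 1 the nearest and beyond the scatter.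

Compound 3, `CC(C)[C@@H](NC(=O)Nc1ccccc1)C(=O)N1CCC(c2ccc(Cl)cc2)CC1`, has not yet been measured. Its change from compound 2 is anilino in place of 2-(2-methylphenyl)ethyl on a carbonyl carbon: the whole chain that carried the aromatic ring is removed, and a nitrogen-linked phenyl ring sits directly on the carbonyl carbon instead. Among the measured compounds shown here, the one measured step only tells how the distal aromatic group matters, and it was modest; nothing measured speaks to losing the chain itself. The change is therefore expected to move this assay only moderately, most likely toward a somewhat higher number, a 2.6-fold higher number from compound 2 to compound 3 (0.42 log units; beyond the scatter). Compound 3 is estimated at 50 nM, within 10 nM to 250 nM.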

Compound 3, half-maximal inhibitory concentration: 616 nM
Beside the measured number, compound 3's estimate is 12-fold (1.09 log units) below it, and the stated range ends below it.
By their numbers in this assay, from the lowest: compound 2; then compound 1; then compound 3.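

In this assay, the earlier change to the aromatic group, a 3.7-fold lower number from compound 1 to compound 2 (0.57 log units; beyond the scatter), was modest, but the link that holds the ring to the carbonyl carbon turns out to matter far more: anilino in place of 2-(2-methylphenyl)ethyl gives a 32-fold higher number from compound 2 to compound 3 (1.51 log units; beyond the scatter), and anilino in place of 2-(4-fluorophenyl)ethyl gives an 8.8-fold higher number from compound 1 to compound 3 (0.94 log units; beyond the scatter). All three groups carry one six-membered aromatic ring, so the presence of a ring alone does not keep the number low, and the anilino group also differs from 2-(2-methylphenyl)ethyl by bringing a hydrogen-bond donor and having fewer heavy atoms. No measurement shown here explains why the number rises.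

These compounds leave open whether the rise follows from the nitrogen, the shorter link or the loss of the methyl or fluorine on the ring, since all of these change together in compound 3. A 2-methylanilino group or an unsubstituted 2-phenylethyl group on the same carbonyl carbon would help separate these possibilities.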